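Phenylethenyl in place of methylphenyl: expectation for compound 3

A few compounds are considered here, and "the series" means these few. Any claim that something is new, unique, unknown or untested is made for them only; others in the source may bear on it.

Compound 1 `COC(=O)/C=C/c1cccc(N(Cc2ccc(/C=C/c3scnc3C)cc2)C(=O)C(C)C)c1` gives 228 nM in an assay on isolated protein with Bile acid receptor (Homo sapiens) as the target; a lower number here means that less compound is needed, a higher number that more compound is needed for the effect. Compound 2 `COC(=O)/C=C/c1cccc(N(Cc2ccc(-c3ccc(C)cc3)cc2)C(=O)C(C)C)c1` gives 118 nM in this assay. Among the measured compounds shown here, the one step available is a 1.9-fold lower number from compound 1 to compound 2 (0.29 log units; within the scatter), so the two compounds cannot be told apart on these numbers, and compound 2 stands level with compound 1 rather than clearly apart from it.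

Compound 3 `COC(=O)/C=C/c1cccc(N(Cc2ccc(/C=C/c3ccccc3)cc2)C(=O)C(C)C)c1` is the next member. Its change from compound 2 is 2-phenylethenyl in place of 4-methylphenyl on an aromatic carbon. For the measured compounds named here, the only step that bears on it is the one from compound 1 to compound 2, which exchanged a five-membered heteroaromatic ring linked through an ethenyl for a directly attached methylphenyl at the same aromatic carbon and stayed within the scatter. Compound 3 brings back the ethenyl linker, now carrying a carbon-only six-membered ring. Because a 1.9-fold lower number from compound 1 to compound 2 (0.29 log units; within the scatter) was small, no step beyond the scatter is expected in this assay in either direction.

The estimate for compound 3 is therefore 170 nM, within 70 nM to 420 nM, a step of a 1.4-fold higher number from compound 2 to compound 3 (0.16 log units; within the scatter) that is expected to stay inside the usual scatter.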

Compound 3, half-maximal effective concentration: 65 nM
The estimate for compound 3 lay 2.6-fold (0.42 log units) above the measured number; measured number below the stated range.
By their numbers in this assay, from the lowest: compounds 3, 2 and 1 (each within the scatter of the next, the first and the last beyond it).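

In this assay, among the compounds shown here, with the ethenyl linker kept, phenyl in place of 4-methyl-1,3-thiazol-5-yl gives a 3.5-fold lower number from compound 1 to compound 3 (0.55 log units; beyond the scatter) and so provides the first step beyond the scatter, showing that the ring at the end of the chain can shift the number modestly. At the aromatic carbon para to a large group, 2-phenylethenyl in place of 4-methylphenyl gives a 1.8-fold lower number from compound 2 to compound 3 (0.26 log units; within the scatter) and leaves the two groups unresolved, so the compounds shown do not establish that the ethenyl linker itself matters. No measurement at hand explains the modest step between the two ethenyl-linked rings.

From the compounds shown here alone, it remains open how a methoxy group or a fluorine on the phenyl ring of the 2-phenylethenyl group, or a saturated two-carbon chain in place of the double bond, would read in this assay. The series also leaves open whether the same ring preference would hold with a carboxylic acid in place of the methyl ester, or with a different acyl group on the amide nitrogen.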